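Notes on amine side-chain variation in the series

The source may hold more compounds than are shown below. What is called first, only, known or untested is meant among the compounds shown, and "the series" means these compounds.

Measured in a functional assay on NCI-H460 cells (Homo sapiens) for cytotoxicity, read by MTT assay, with a stated time of 72 h; on this read-out higher numbers stand for weaker inhibition and lower numbers for stronger inhibition:
compound 1 `CN(C)CCNc1nc(-c2ccc(NC(=O)Nc3ccccc3)cc2)nc2ccsc12`: 640 nM
compound 2 `Cc1ccc(NC(=O)Nc2ccc(-c3nc(NCCN(C)C)c4sccc4n3)cc2)cc1`: 1880 nM
compound 3 `CCN(CC)CCCNc1nc(-c2ccc(NC(=O)Nc3ccccc3)cc2)nc2ccsc12`: not yet measured

Compound 1 gives the lowest of the two numbers; the nearest is compound 2, reached by a 2.9-fold higher number from compound 1 to compound 2 (0.47 log units; beyond the scatter), a methyl in place of hydrogen on an aromatic carbon. Compound 3 differs from compound 1 by (diethylamino)methyl in place of dimethylamino on a saturated chain carbon, two bonds along the chain from a nitrogen on an aromatic ring. Within the data shown here, the one measured step concerns the urea-side aryl and not the amine chain, so no measured step bears on this change. Among the measured compounds shown here, with no precedent, the expectation is no step beyond the scatter, with wide uncertainty. Compound 3 is expected at 800 nM, in the range 300 nM to 2500 nM, which means an expected 1.3-fold higher number from compound 1 to compound 3 (0.10 log units; within the scatter).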

Compound 3, half-maximal inhibitory concentration: 680 nM
Compound 3: middle estimate off by 1.2-fold (0.07 log units), on the high side; the range from low to high includes it.
By their numbers in this assay, from the lowest: compounds 1 and 3 (each within the scatter of the next); then compound 2.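

In this assay, going from the 2-(dimethylamino)ethyl chain to the 3-(diethylamino)propyl chain gives a 1.1-fold higher number from compound 1 to compound 3 (0.03 log units; within the scatter) and so provides the first read on the amine chain: this position accepts the longer chain carrying the larger amine without a step beyond the scatter. No available evidence accounts for this outcome.

Among these compounds, the single step changes chain length and the amine's alkyl groups together, so their separate contributions remain unresolved. Open too, as far as these compounds go, is how a ring amine such as morpholine or piperidine would fare on this chain.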